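A few compounds are considered here, and "the series" means these few. Any claim that something is new, unique, unknown or untested is made for them only; others in the source may bear on it.

For the measured compounds named here, in an ADME assay on cells (Hepatocyte, Rattus norvegicus) for metabolic stability (on this read-out higher numbers stand for a longer-lived compound and lower numbers for a shorter-lived compound), compound 1 `N#Cc1ccc(N2CCC(C(=O)N3N=CC[C@H]3c3cc(F)cc(F)c3)CC2)nn1` gives 2.08 h as the only actual number in this small set. Compound 2 `O=C(C1CCN(c2cccnn2)CC1)N1N=CC[C@H]1c1ccccc1` stands at < 0.517 h which is a limit of the assay and not a number. Compound 3 `N#Cc1cc(N2CCC(C(=O)N3N=CC[C@H]3c3cc(F)cc(F)c3)CC2)ncn1` has the same atoms as compound 1 joined differently, and the change is a group of 8 heavy atoms (5 carbon, 3 nitrogen; one six-membered aromatic ring with 2 hetero atoms) in place of a group of 8 heavy atoms (5 carbon, 3 nitrogen; one six-membered aromatic ring with 2 hetero atoms), on an amine nitrogen in a ring on an amine nitrogen in a ring, with the rest of the molecule untouched. Going by the values given here, no measured pair shows a change of this kind, so compound 1 at 2.08 h is the only anchor. In this assay no shift beyond the usual scatter is expected in either direction. The estimated change is a 1.2-fold lower number from compound 1 to compound 3 (0.06 log units; within the scatter) in size. For compound 3 the expected half-life is 1.8 h within an estimated range of 0.7 h to 4.5 h as a rough guide.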

Compound 3, half-life: 1.15 h
Beside the measured number, compound 3's estimate is 1.6-fold (0.19 log units) above it, and the stated range covers the measured number.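

In this assay, for the compounds shown here, this is the first comparison in which only one place differs: on the amine nitrogen of the six-membered non-aromatic ring, one nitrile-bearing aromatic ring with 2 hetero atoms gives way to another built from the same atoms joined differently, giving a 1.8-fold lower number from compound 1 to compound 3 (0.26 log units; within the scatter). The two compounds therefore read alike, and at this position this rearrangement of atoms does not move the half-life beyond the usual scatter. Nothing measured here accounts for the step.

Compound 2 stands at a limit and not a number, and it differs from the others in more than one place, so steps to it cannot be read. On these data alone, how a phenyl ring on that amine nitrogen, or a carboxylic acid in place of the nitrile, would behave stays open, as does the part played by the fluorine atoms.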